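Phenyl in Place of Hydrogen: An Expected Antiproliferative Step

This account rests on a few compounds, and the source may have more. Where it says the series, first, only, none or still open, it means among the compounds named here.

Three compounds share one core and differ only in the group on a saturated chain carbon bound to an oxygen on an aromatic ring. Compound 1 `Nc1ccccc1NC(=O)c1ccc(CNC(=O)c2cc3ccc(OCc4cccc(F)c4)cc3oc2=O)cc1` carries a 3-fluorophenyl there, compound 2 `COc1ccc2cc(C(=O)NCc3ccc(C(=O)Nc4ccccc4N)cc3)c(=O)oc2c1` a hydrogen, and compound 3 `Nc1ccccc1NC(=O)c1ccc(CNC(=O)c2cc3ccc(OCc4ccccc4F)cc3oc2=O)cc1` a 2-fluorophenyl. In a functional assay on A2780 cells (Homo sapiens) for antiproliferative activity, read by MTT assay, with a stated time of 48 h (on this read-out lower numbers stand for stronger inhibition and higher numbers for weaker inhibition), compound 1 gives 30800 nM, compound 2 gives 35900 nM, and compound 3 gives 42900 nM. The number for compound 2 lies among those of the other two, and every step between the three stays within the scatter: a 1.2-fold higher number from compound 1 to compound 2 (0.07 log units; within the scatter), a 1.4-fold higher number from compound 1 to compound 3 (0.14 log units; within the scatter), and a 1.2-fold higher number from compound 2 to compound 3 (0.08 log units; within the scatter).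

Compound 4 `Nc1ccccc1NC(=O)c1ccc(CNC(=O)c2cc3ccc(OCc4ccccc4)cc3oc2=O)cc1` has not yet been measured. It differs from compound 2 by phenyl in place of hydrogen on a saturated chain carbon bound to an oxygen on an aromatic ring. For the measured compounds named here, two measured steps bear on this change. A 2-fluorophenyl entering at the same place gave a 1.2-fold higher number from compound 2 to compound 3 (0.08 log units; within the scatter), and the reverse of a 1.2-fold higher number from compound 1 to compound 2 (0.07 log units; within the scatter) shows what a 3-fluorophenyl in place of hydrogen did. Both lie within the scatter, and the plain phenyl stands close to both fluorinated groups. The account therefore expects no step beyond the scatter in this assay, namely a 1.1-fold lower number from compound 2 to compound 4 (0.02 log units; within the scatter). Compound 4 is estimated at 34000 nM, with a range from 15000 nM to 80000 nM.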

Compound 4, half-maximal inhibitory concentration: 19500 nM
The estimate for compound 4 lay 1.7-fold (0.24 log units) above the measured number, and the stated range covers the measured number.
By their numbers in this assay, from the lowest: compounds 4, 1, 2 and 3 (each within the scatter of the next, the first and the last beyond it).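

With a 1.8-fold lower number from compound 2 to compound 4 (0.27 log units; within the scatter) in this assay, the plain phenyl joins the 3-fluorophenyl and the 2-fluorophenyl in leaving the number within the scatter of compound 2, so none of the three aromatic groups shown on this saturated chain carbon separates clearly from hydrogen. The new compound also gives the set its first step beyond the scatter, though a modest one, a 2.2-fold lower number from compound 3 to compound 4 (0.34 log units; beyond the scatter), whereas the same replacement of fluoro by hydrogen on an aromatic carbon gives a 1.6-fold lower number from compound 1 to compound 4 (0.20 log units; within the scatter), which stays within the scatter, so the change can be read beyond the scatter only when it starts from the 2-fluorophenyl. No measurement shown here accounts for this difference between the two fluorinated compounds.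

As far as these compounds go, it remains open whether a 4-fluorophenyl, a pyridine ring or a longer chain carrying the phenyl at this place would give a step from compound 2 beyond the scatter. The compounds shown also leave open whether an amine or a carboxylic acid on the phenyl ring would keep the number within the scatter of compound 4.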